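The source may hold more compounds than are shown below. What is called first, only, known or untested is meant among the compounds shown, and "the series" means these compounds.

Of the compounds shown here, three in this set have already been measured in an ADME assay for permeability, using PAMPA, at pH 5.5; on this read-out lower numbers stand for lower permeability and higher numbers for higher permeability. Compound 3 `Cn1cc(-c2ccc(C(F)(F)F)cc2)c2ccc(C(=O)NS(C)(=O)=O)cc21` gives 972 nm/s in this assay. Compound 1 `Cn1cc(-c2ccc(C(F)(F)F)cc2)c2ccc(C(=O)NS(=O)(=O)C3CC3)cc21` differs from compound 3 in one place only, (cyclopropyl in place of methyl on a sulfonyl sulfur); in this assay compound 1 gives 525 nm/s. The step between the two is a 1.9-fold lower number from compound 3 to compound 1 (0.27 log units; within the scatter), so the change did not move the number by more than repeated measurements of the same compound usually do.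

Compound 2 `CC(C)COc1ccc(-c2cn(C)c3cc(C(=O)NS(C)(=O)=O)c(F)cc23)cn1` is built on a different core, and the difference between the two cores is not broken down here. In this assay compound 2 gives 802 nm/s, a number that lies within the scatter of those of compound 3 and of compound 1.

Compound 4 `CC(C)COc1ccc(-c2cn(C)c3cc(C(=O)NS(=O)(=O)C4CC4)c(F)cc23)cn1` has not yet been measured. It is compound 2 with cyclopropyl in place of methyl on a sulfonyl sulfur. The place of this change, a sulfonyl sulfur whose other neighbour is an amide-type nitrogen, is the same in both pairs, so this is the same change that was made from compound 3 to compound 1, now made on the core of compound 2.

Among the compounds with values here, the only guide is that one earlier step. For compound 4 the expected step is a 1.8-fold lower number from compound 2 to compound 4 (0.25 log units; within the scatter), because a 1.9-fold lower number from compound 3 to compound 1 (0.27 log units; within the scatter) on the other core stayed within the scatter. Compound 4 is therefore expected to give about 450 nm/s in this assay, most likely between 250 nm/s and 800 nm/s.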

Compound 4, apparent permeability: 851 nm/s
Beside the measured number, compound 4's estimate is 1.9-fold (0.28 log units) below it, outside the stated range (above it).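

In this assay, the step for cyclopropyl in place of methyl on a sulfonyl sulfur is a 1.1-fold higher number from compound 2 to compound 4 (0.03 log units; within the scatter), so on the core of compound 2 the change moves the number no more than repeated measurements of one compound usually do. Set beside the earlier step, the result gives no sign that the two cores respond differently, even though the two steps point in opposite directions on paper: the same change on two cores in this assay, a 1.9-fold lower number (0.27 log units; within the scatter) from compound 3 to compound 1 and a 1.1-fold higher number (0.03 log units; within the scatter) from compound 2 to compound 4, 2.0-fold (0.29 log units) apart, within the scatter of two such steps. In both pairs shown, then, this change stays within the scatter, which is useful but limited: two pairs cannot show that the same would hold on every core in this series, and a real but small difference between these two cores could lie hidden inside the scatter.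

The compounds shown leave open whether a larger group on the sulfonyl sulfur, such as a longer carbon chain, a phenyl ring or a dimethylamino group, would also stay within the scatter. They also leave open how the step from methyl to cyclopropyl would look on a third core, and they say nothing about it in any read-out other than this assay.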